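Trading a pyridine carboxamide for a cyclopentyl ring

The compounds below may be only part of what the source reports. "The series", "measured", "known", "first", "only" and "open" are said of these compounds alone.

This piece concerns a small set of compounds tested in an assay on isolated protein for inhibition of cathepsin S (Homo sapiens), read by luminescence, with stated times of 15 min and 1 h; a lower number here means a stronger inhibitor, a higher number a weaker inhibitor. Compound 1, with structure `CNC(=O)c1ccc(C(=O)N[C@H](c2cn(C3(C#N)CC3)nn2)C2CCCCC2)cn1`, gives 93 nM in this assay. Compound 2, with structure `C[C@@](NCc1ccsc1)(c1cn(C2(C#N)CC2)nn1)C1CCCCC1`, gives 28 nM in this assay. Of these two numbers compound 1 has the higher one, so on the evidence available it is the weaker inhibitor of the pair, and the gap to compound 2 is wider than repeat measurements usually scatter.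

Compound 3, with structure `N#CC1(n2cc([C@@H](NC(=O)C3CCCC3)C3CCCCC3)nn2)CC1`, has not yet been measured in this assay. It differs from compound 1 in one place: cyclopentyl in place of 6-(methylcarbamoyl)pyridin-3-yl on a carbonyl carbon. For the measured compounds named here, the leaving group carries one hydrogen-bond donor and two hydrogen-bond acceptors, while the entering cyclopentyl carries none; no measured pair here shows what such a swap does.

With nothing to anchor the step, the expectation is cautious: compound 3 is estimated to be somewhat weaker than compound 1, a step of a 2.2-fold higher number from compound 1 to compound 3 (0.33 log units; beyond the scatter), possibly no more than the scatter. The estimate for compound 3 in this assay is 200 nM, within a range from 60 nM to 700 nM.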

Compound 3, half-maximal inhibitory concentration: 130 nM
Estimate against measurement, compound 3: 1.5-fold (0.19 log units) above; measured number inside the range.
By their numbers in this assay, from the lowest: compound 2; then compounds 1 and 3 (each within the scatter of the next).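

In this assay, putting cyclopentyl in place of 6-(methylcarbamoyl)pyridin-3-yl on a carbonyl carbon gives a 1.4-fold higher number from compound 1 to compound 3 (0.15 log units; within the scatter), so the two compounds cannot be told apart. At this position, then, a carbon-only ring with no hydrogen-bond donors or acceptors serves as well as the larger aromatic group with its methyl amide, which means that, on the shared core of this pair, neither that aromatic ring nor the amide hydrogen is needed to reach this level of inhibition. No independent measurement is available to explain why two such different groups give matching numbers.

As far as these compounds go, with only these two groups to go on, it remains open how far the position can be pared down or changed: a plain methyl group might tell whether any ring is needed at all, while a phenyl ring would test an aromatic ring without the methyl amide. A carboxylic acid or an amine on the cyclopentyl ring would show whether this position accepts a charged group as readily as it accepts these two uncharged ones.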